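Carbamate series: from compound 3 to compound 4

This account rests on a few compounds, and the source may have more. Where it says the series, first, only, none or still open, it means among the compounds named here.

Measured so far:
compound 1 `N#C[Se]c1ccc(NC(=O)OCc2ccc([N+](=O)[O-])cc2)cc1`, 9000 nM
compound 2 `N#C[Se]c1ccc(NC(=O)Oc2ccc(F)cc2)cc1`, 11800 nM
compound 3 `N#C[Se]c1ccc(NC(=O)OCc2ccccc2)cc1`, 3700 nM

In a functional assay on PC-3 cells (Homo sapiens) for cytotoxicity, read by MTT assay, with a stated time of 72 h (a lower number here means a stronger inhibitor of growth, a higher number a weaker inhibitor of growth), compound 3 gives the lowest number of the three; compound 1 stands a step above it, a 2.4-fold lower number from compound 1 to compound 3 (0.39 log units; beyond the scatter), and compound 2 stands higher still. Compound 4 `CC(C)COC(=O)Nc1ccc([Se]C#N)cc1` differs from compound 3 in one place: isopropyl in place of phenyl on a saturated chain carbon bound to an oxygen next to a carbonyl group. Among the measured compounds shown here, no measured step touches this position; the only step in hand, from compound 1 to compound 3, concerns a substituent on the aromatic ring, and compound 2 differs from compound 3 in more than one place. The expectation for compound 4 therefore rests on compound 3 alone, with a step of a 1.5-fold higher number from compound 3 to compound 4 (0.17 log units; within the scatter) expected, not clearly beyond the scatter. Compound 4 is estimated at 5500 nM, range 2000 nM to 15000 nM.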

Compound 4, concentration for 50% growth inhibition: 21600 nM
Compound 4: middle estimate off by 3.9-fold (0.59 log units), on the low side; measured number outside the range, above it.
By their numbers in this assay, from the lowest: compound 3; then compounds 1, 2 and 4 (each within the scatter of the next, the first and the last beyond it).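

In this assay, isopropyl in place of phenyl on a saturated chain carbon bound to an oxygen next to a carbonyl group gives a 5.8-fold higher number from compound 3 to compound 4 (0.77 log units; beyond the scatter), the first step read at this position. The position is therefore not indifferent to this change: here, loss of the aromatic ring goes with weaker growth inhibition. Nothing measured on hand accounts for the step.

On these data alone, whether the aromatic ring itself matters, or only its carbon count, stays open. A cyclohexyl group or a longer chain in the same place would separate the two.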